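Swapping a Chloro for a Methoxycarbonyl on the Amide Arm

This account rests on a few compounds, and the source may have more. Where it says the series, first, only, none or still open, it means among the compounds named here.

Among the compounds with values here, compound 1 `COc1cc2oc(-c3cccc(NC(=O)c4ccc(Cl)cc4)c3)cc(=O)c2c(OC)c1OC` is the only compound here with a number: in a functional assay on UO-31 cells (Homo sapiens) for inhibition, read by sulforhodamine B assay, tested at 10 uM (on this read-out lower numbers stand for less inhibition and higher numbers for more inhibition at the one concentration tested (going by the name of the read-out)), compound 1 gives 51.1%. A close relative, compound 2 `COc1cc2oc(-c3cccc(NC(=O)c4ccc(C#N)cc4)c3)cc(=O)c2c(OC)c1OC`, is reported in this assay only as "active" (no number reported), with no number attached. Compound 3 `COC(=O)c1ccc(C(=O)Nc2cccc(-c3cc(=O)c4c(OC)c(OC)c(OC)cc4o3)c2)cc1` carries the change (methoxycarbonyl in place of chloro on an aromatic carbon). With no measured step of this kind among these compounds to lean on, the expected step of a number 3.1 percentage points lower from compound 1 to compound 3 (within the scatter) is small, no larger than the usual scatter, in either direction. Compound 3 is therefore estimated at 48%, within a range from 25% to 70%.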

Compound 3, a percentage reported as inhibition, at one concentration (the size of the read-out at that concentration, not a potency): "active" (no number reported)
The entry for compound 3 holds no number; no gap can be computed for the estimate.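

Within the data shown here, compound 3 has no number in this assay, so no step from compound 1 to compound 3 can be read. From the compounds shown here alone, how methoxycarbonyl compares with chloro on inhibition stays open. No other data here bear on this result.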